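A few compounds are considered here, and "the series" means these few. Any claim that something is new, unique, unknown or untested is made for them only; others in the source may bear on it.

Measured so far in a functional assay on MCF7 cells (Homo sapiens) for antiproliferative activity, read by MTT assay, with a stated time of 48 h; a lower number here means a stronger inhibitor, a higher number a weaker inhibitor:

- compound 1 `Cc1ccc2nc(NC(c3cn(-c4ccccc4)nc3-c3cccc([N+](=O)[O-])c3)c3c(O)ccc4ccccc34)sc2c1`: 38400 nM
- compound 2 `Oc1ccc2ccccc2c1C(Nc1nc2ccccc2s1)c1cn(-c2ccccc2)nc1-c1ccccc1`: 48900 nM

Compound 2 stands at 48900 nM and compound 1 at 38400 nM, and these two values lie within the scatter of each other. Among the measured compounds shown here, the pair therefore sets one level for the series so far, and neither compound can be ranked over the other.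

The next compound is compound 3 `Cc1cccc(-c2nn(-c3ccccc3)cc2C(Nc2nc3ccccc3s2)c2c(O)ccc3ccccc23)c1`, which differs from compound 2 at a single place, with methyl in place of hydrogen on an aromatic carbon. The exchange turns phenyl into 3-methylphenyl. For the measured compounds named here, the measured compounds offer no single-place step, so nothing shows directly what this exchange does in this assay. No direction is expected, and no step beyond the scatter. The expectation rests only on the level set by compound 2 at 48900 nM.

The estimate corresponds to a 1.2-fold lower number from compound 2 to compound 3 (0.07 log units; within the scatter), an expected step that stays within the scatter. For compound 3 the expected value is 42000 nM, with an estimated range of 20000 nM to 85000 nM.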

Compound 3, half-maximal inhibitory concentration: 17300 nM
Compound 3: middle estimate off by 2.4-fold (0.39 log units), on the high side; measured number below the stated range.
By their numbers in this assay, from the lowest: compound 3; then compounds 1 and 2 (each within the scatter of the next).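

In this assay, among the compounds shown here, the exchange of phenyl for 3-methylphenyl provides the first single-place step, giving a 2.8-fold lower number from compound 2 to compound 3 (0.45 log units; beyond the scatter) and marking a modest change beyond the scatter. This position is therefore not indifferent to substitution: a single added carbon, on an aromatic carbon of a six-membered aromatic ring of carbon only and meta to a large group, is enough to shift the reading toward a stronger inhibitor. No available measurement bears on the reason for the shift, so the step stands as an observation only.

From the compounds shown here alone, it remains open whether the shift is particular to methyl or would also follow from other groups at this place, since a single substituent in a single assay cannot separate the two, and a methoxy group, a chlorine atom or an ethyl group there would bear on that question. Going by these compounds, it also remains open whether the same exchange would have a similar effect in other members, such as compound 1, which differs from compound 3 in more than one place.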